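A Benzoyl Swap at the Cytotoxicity Limit

A few compounds are considered here, and "the series" means these few. Any claim that something is new, unique, unknown or untested is made for them only; others in the source may bear on it.

Compound 1 `CCC(CC)O[C@@H]1C=C(C(=O)O)C[C@H](NCc2ccc(OC(C)C)cc2)[C@H]1NC(C)=O` gives > 200000 nM (a limit)
Compound 2 `CCC(CC)O[C@@H]1C=C(C(=O)O)C[C@H](NCc2ccc(SCC(C)C)cc2)[C@H]1NC(C)=O` gives > 200000 nM (a limit)
Compound 3 `CCC(CC)O[C@@H]1C=C(C(=O)O)C[C@H](NCc2ccc(-c3ccc4sccc4c3)cc2)[C@H]1NC(C)=O` gives > 200000 nM (a limit)

All three compounds share one core and differ only in the group on an aromatic carbon. They were tested in an ADME assay on cells (Fibroblast, Gallus gallus) for cytotoxicity, read by CCK-8 assay, with a stated time of 48 h (on this read-out higher numbers stand for lower toxicity in this test and lower numbers for higher toxicity in this test), and none returned a number. Compound 3 stands at the limit of > 200000 nM in this assay, at which 3 of the 3 values shown sit, and has no number of its own.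

Compound 4 `CCC(CC)O[C@@H]1C=C(C(=O)O)C[C@H](NCc2ccc(C(=O)c3ccccc3)cc2)[C@H]1NC(C)=O` has not yet been measured. It carries benzoyl in place of 1-benzothiophen-5-yl on an aromatic carbon and is otherwise the same as compound 3.

Three measured steps changed the group at this place: a step that the two limits leave unreadable from compound 1 to compound 2 and a step that the two limits leave unreadable from compound 1 to compound 3 and a step that the two limits leave unreadable from compound 2 to compound 3 give no size to carry over. No size or direction can be drawn from them, so no step beyond the scatter is expected in this assay for this change. Compound 3 gives > 200000 nM as a limit, so the reading for compound 4 is expected to lie around that limit and most probably to come back as a limit again. The expected change is a number no higher from compound 3 to compound 4 (the limit leaves the size open) as estimated here. For compound 4 the estimated value is 200000 nM with an expected range from 100000 nM to 400000 nM in this test.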

Compound 4, half-maximal cytotoxic concentration: > 200000 nM
Compound 4: a limit, no number (the forecaster's own chance of this, stated with the estimate: 85%); the middle value lies on the limit itself.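

In this assay compound 4 gives > 200000 nM, which is a limit and not a number. No step can be read between compound 1, compound 2, compound 3 and compound 4, since all four readings are limits: the limit of > 200000 nM in this assay, at which 4 of the 4 values shown sit. The compounds shown leave open whether these four groups differ at all in this test, and in which order.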